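The source may hold more compounds than are shown below. What is called first, only, known or untested is meant among the compounds shown, and "the series" means these compounds.

Measured compounds:
- Compound 1, `CCOC(=O)c1cnn(-c2nc(-c3ccccc3F)c(C#N)c(=O)n2C)c1N`: in a functional assay, with a stated time of 20 min (a lower number here means a stronger inhibitor, a higher number a weaker inhibitor), compound 1 gives 69 ug/mL.
- Compound 2, `CCOC(=O)c1cnn(-c2nc(-c3cccc(OC)c3OC)c(C#N)c(=O)n2C)c1N`: in this assay compound 2 gives 54 ug/mL.
- Compound 3, `CCOC(=O)c1cnn(-c2nc(-c3ccco3)c(C#N)c(=O)n2C)c1N`: in this assay compound 3 gives 91 ug/mL.

All three share one core and differ only in the aromatic group attached to it. Compound 3 carries the highest of the three numbers, but every gap to the others lies within the scatter: a 1.3-fold higher number from compound 1 to compound 3 (0.12 log units; within the scatter) and a 1.7-fold higher number from compound 2 to compound 3 (0.23 log units; within the scatter). So far, then, changing this aromatic group has not moved the read-out beyond what repeated measurements would show anyway.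

Compound 4, `CCOC(=O)c1cnn(-c2nc(-c3cccs3)c(C#N)c(=O)n2C)c1N`, continues the same kind of change: thiophen-2-yl in place of furan-2-yl on an aromatic carbon. The two steps that bear on it, from compound 1 to compound 3 and from compound 2 to compound 3, were both within the scatter, so in this assay no step beyond the scatter is expected here either. Compound 4 is therefore estimated at 80 ug/mL, with a range from 40 ug/mL to 160 ug/mL, a step of a 1.1-fold lower number from compound 3 to compound 4 (0.06 log units; within the scatter) that is expected to stay within the usual spread.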

Compound 4, half-maximal inhibitory concentration: 79 ug/mL
The estimate for compound 4 lay 1.0-fold (0.01 log units) above the measured number; the measured number falls inside the stated range.
By their numbers in this assay, from the lowest: compounds 2, 1, 4 and 3 (each within the scatter of the next).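

Replacing furan-2-yl with thiophen-2-yl exchanges a ring oxygen for a ring sulfur while keeping a five-membered aromatic ring at this position, ortho to the cyano group, and in this assay this gives a 1.2-fold lower number from compound 3 to compound 4 (0.06 log units; within the scatter) and so no readable change. Compound 4 also stays level with both phenyl-bearing compounds, with a 1.5-fold higher number from compound 2 to compound 4 (0.17 log units; within the scatter) and a 1.1-fold higher number from compound 1 to compound 4 (0.06 log units; within the scatter), so a sulfur-containing ring now joins the fluorine, methoxy and furan variants in leaving the number within the scatter. No measurement here offers a reason why these groups read alike.

On these data alone, all four groups are aromatic rings, so it stays open whether an amine, a carboxylic acid or a longer alkyl chain on this carbon would move the number beyond the scatter. As far as these compounds go, the part of the molecule outside this position, such as the ethyl ester, also stays open, as it is the same in all four compounds.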